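The source may hold more compounds than are shown below. What is called first, only, known or untested is meant among the compounds shown, and "the series" means these compounds.

Measured so far:
- compound 1 `CCC(=O)c1cc(-c2ccc(C)cc2)n(-c2ccc(S(N)(=O)=O)cc2)c1C`: 1000 nM
- compound 2 `CCOC(=O)c1cc(-c2ccc(OC)cc2)n(-c2ccc(S(N)(=O)=O)cc2)c1C`: 16100 nM
- compound 3 `CCOC(=O)c1cc(-c2cccc(Cl)c2)n(-c2ccc(S(N)(=O)=O)cc2)c1C`: 9200 nM

These numbers come from a physicochemical assay for solubility, read by HPLC, in phosphate buffer, measured as kinetic solubility, at pH 7.4; a higher number here means a more soluble compound, a lower number a less soluble compound. Compound 3, at 9200 nM, sits level with compound 2, while compound 1 lies lower, beyond the scatter. Compound 4 `CCOC(=O)c1cc(-c2ccc(C)cc2)n(-c2ccc(S(N)(=O)=O)cc2)c1C` differs from compound 3 by one change: 4-methylphenyl in place of 3-chlorophenyl on an aromatic carbon. Going by the values given here, one measured step bears on it, a swap of the group at that same place, which gave a 1.8-fold lower number from compound 2 to compound 3 (0.24 log units; within the scatter). Compound 1 also carries 4-methylphenyl but lacks the ethoxycarbonyl group, so its 1000 nM is only a weak hint of a lower number. The expected change stays within the scatter: a 1.4-fold lower number from compound 3 to compound 4 (0.15 log units; within the scatter). For compound 4 the estimate is 6500 nM, with an expected range of 2200 nM to 17000 nM.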

Compound 4, solubility: 1300 nM
Compound 4: middle estimate off by 5.0-fold (0.70 log units), on the high side; measured number outside the range, below it.
By their numbers in this assay, from the lowest: compounds 1 and 4 (each within the scatter of the next); then compounds 3 and 2 (each within the scatter of the next).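

Going by these compounds alone, the group at this position counts for more in this assay than the earlier compounds suggested. Putting 4-methylphenyl in place of 3-chlorophenyl gives a 7.1-fold lower number from compound 3 to compound 4 (0.85 log units; beyond the scatter) and methyl in place of methoxy on the phenyl ring gives a 12-fold lower number from compound 2 to compound 4 (1.09 log units; beyond the scatter) so the aromatic group here is not interchangeable. Ethoxy in place of ethyl on the carbonyl carbon gives a 1.3-fold higher number from compound 1 to compound 4 (0.11 log units; within the scatter) so the two compounds carrying 4-methylphenyl sit level.

From the compounds shown here alone, whether an amine or a carboxylic acid on that phenyl ring would shift the number stays open. Nothing available explains the drop.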